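Hydroxypropyl for propyl on a second aryl amine core

This account rests on a few compounds, and the source may have more. Where it says the series, first, only, none or still open, it means among the compounds named here.

Measured so far:
compound 3 `CCCN(Cc1ccccc1)c1ccc(C(=O)N2CCc3ccc(OS(N)(=O)=O)cc3C2)cc1` gives 64.8%
compound 2 `CCCN(Cc1ccccc1)c1cccc(C(=O)N2CCc3ccc(OS(N)(=O)=O)cc3C2)c1` gives 23.1%
compound 1 `NS(=O)(=O)Oc1ccc2c(c1)CN(C(=O)c1ccc(N(CCCO)Cc3ccccc3)cc1)CC2` gives 5.7%

All three were tested in an assay on HEK293 cells for inhibition of Steryl-sulfatase (Homo sapiens), tested at 0.1 uM; a lower number here means a weaker effect, a higher number a stronger effect of the compound at the concentration tested. Compound 3 stands highest, compound 2 is the second highest of the three, and compound 1 comes lowest. Compound 2 and compound 3 are built from the same atoms joined differently; how their two cores differ is not broken down here.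

One change connects compound 3 to compound 1: hydroxy in place of hydrogen on a saturated chain carbon, three bonds along the chain from a nitrogen on an aromatic ring. That step, a number 59.1 percentage points lower from compound 3 to compound 1 (beyond the scatter), cost most of the inhibition seen for compound 3.

Compound 4 `NS(=O)(=O)Oc1ccc2c(c1)CN(C(=O)c1cccc(N(CCCO)Cc3ccccc3)c1)CC2` has not been measured in this assay. It is obtained from compound 2 by the same kind of change, (hydroxy in place of hydrogen on a saturated chain carbon, three bonds along the chain from a nitrogen on an aromatic ring), and both differences carry the same wording of place, so the two changes are of the same kind on two different cores. Because compound 2 starts from 23.1%, there is less room to fall than there was for compound 3, and the step is expected to be smaller in size than the earlier one: an estimated a number 17.1 percentage points lower from compound 2 to compound 4 (beyond the scatter). Among the measured compounds shown here, the expectation rests on the single pair of compound 3 and compound 1 alone, and nothing more is known of how the second core responds. Compound 4 is therefore expected to show about 6% in this assay, with a likely range from 0% to 18%.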

Compound 4, a percentage reported as inhibition, at one concentration (the size of the read-out at that concentration, not a potency): 25.8%
Beside the measured number, compound 4's estimate is 19.8 percentage points below it, outside the stated range (above it).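

In this assay, the change from propyl to 3-hydroxypropyl gives a number 2.7 percentage points higher from compound 2 to compound 4 (within the scatter), so on this core the two compounds cannot be told apart. The change therefore does not carry over from one core to the other with the same outcome, and the two steps clearly differ: the same change on two cores in this assay, a number 59.1 percentage points lower (beyond the scatter) from compound 3 to compound 1 and a number 2.7 percentage points higher (within the scatter) from compound 2 to compound 4, 61.8 percentage points apart, beyond the scatter of two such steps. Among the compounds shown here, this shows that the large loss on the core of compound 3 cannot be treated as a general result of adding the hydroxy, but it does not show why the two cores respond differently, and with only one pair on each core it says nothing about how any further core would respond.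

The compounds shown leave open whether this difference between the cores would persist with other chains on the same nitrogen, such as 2-hydroxyethyl, a longer chain ending in hydroxy, or a chain ending in an amine or a carboxylic acid. They also leave open whether the same contrast would appear across a range of concentrations, since each compound is represented here by a read-out at a single concentration and not by a potency.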